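The source may hold more compounds than are shown below. What is called first, only, known or untested is meant among the compounds shown, and "the series" means these compounds.

Compound 3, `CCOc1ccc(-c2ncnn2-c2cc(OC)c(OC)c(OC)c2)cc1Cl`, stands alone among the three measured compounds in giving a number in a functional assay on K562 cells (Homo sapiens) for antiproliferative activity, read by MTT assay, with a stated time of 72 h; a higher number here means a weaker inhibitor, a lower number a stronger inhibitor: compound 3 gives 20 nM, the strongest inhibition shown. The other two values are limits of the assay. Compound 1, `COc1cc(-n2ncnc2-c2ccccc2)cc(OC)c1OC`, gives only the limit > 10000 nM in this assay. Compound 2, `COc1cc(-n2ncnc2-c2cccc(Cl)c2)cc(OC)c1OC`, likewise gives only the limit > 10000 nM in this assay. Because two of the three values sit at the limit of > 10000 nM in this assay, at which 2 of the 3 values shown sit, the step that the two limits leave unreadable from compound 1 to compound 2 cannot be read. Going by the values given here, the one readable step, an at least 500-fold lower number from compound 2 to compound 3 (2.69 log units; beyond the scatter), shows that the ethoxy group carries the whole measurable gain.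

Compound 4, `COc1cc(-n2ncnc2-c2ccc(Cl)c(Cl)c2)cc(OC)c1OC`, is the next compound in this series. It differs from compound 3 by chloro in place of ethoxy on an aromatic carbon. The step that bears on this change is an at least 500-fold lower number from compound 2 to compound 3 (2.69 log units; beyond the scatter): taking the ethoxy away in compound 4 is expected to undo most of that gain, giving a step of a 400-fold higher number from compound 3 to compound 4 (2.60 log units; beyond the scatter), a much higher number in this assay. The added chloro in compound 4 has no readable precedent, since compound 2 with one chloro gave only a limit. Compound 4 is therefore expected to give about 8000 nM in this assay, within a range from 1500 nM to 40000 nM, with a fair chance that only a limit is returned.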

Compound 4, half-maximal inhibitory concentration: > 10000 nM
Compound 4 was reported as a limit; the forecaster's own chance of this, stated with the estimate: 55%; middle value at least 1.2-fold (0.09 log units) away from the limit.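

In this assay, going by these compounds alone, the change on the aromatic carbon ortho to a chloro group gives an at least 500-fold higher number from compound 3 to compound 4 (2.69 log units; beyond the scatter), so a chloro group at this place does not stand in for the ethoxy group, and the earlier compounds had set only hydrogen against ethoxy there. Compound 4 gives only a limit, > 10000 nM. With hydrogen and chloro at this place, no number is returned, and only the ethoxy group of compound 3 gives one, while the steps from compound 1 and from compound 2 to compound 4 cannot be read because all of these values are limits: the limit of > 10000 nM in this assay, at which 3 of the 4 values shown sit.

The compounds shown do not tell whether the oxygen alone is enough, as a hydroxy group would test, or whether the two carbons of the ethoxy group also matter, as a methoxy group or a longer chain such as propoxy would test. They also leave open whether the neighbouring chloro group of compound 3 is needed at all for the ethoxy group to give its number.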